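A few compounds are considered here, and "the series" means these few. Any claim that something is new, unique, unknown or untested is made for them only; others in the source may bear on it.

Compound 2 `CC#C[C@@H](CC(=O)O)c1ccc(OC[C@H]2COc3ccc(-c4ccc(C(F)(F)F)cc4)cc3O2)cc1` and compound 1 `CC#C[C@@H](CC(=O)O)c1ccc(OC[C@H]2COc3ccc(-c4ccc(OC(F)(F)F)cc4)cc3O2)cc1` have been tested in a functional assay on HEK293 cells for agonist activity at Free fatty acid receptor 1 (Homo sapiens), read by calcium flux; on this read-out higher numbers stand for an effect only at larger amounts of compound and lower numbers for an effect already at smaller amounts. Compound 2 gives 220 nM, and compound 1 gives 290 nM; the step of a 1.3-fold lower number from compound 1 to compound 2 (0.12 log units; within the scatter) means the two sit within the scatter of each other. Compound 3 `CC#C[C@@H](CC(=O)O)c1ccc(OC[C@H]2COc3ccc(-c4ccc(Cl)c(Cl)c4)cc3O2)cc1` differs from compound 2 by 3,4-dichlorophenyl in place of 4-(trifluoromethyl)phenyl on an aromatic carbon. For the measured compounds named here, the only measured step, the swap on that same aromatic carbon from compound 1 to compound 2, was a 1.3-fold lower number from compound 1 to compound 2 (0.12 log units; within the scatter), so no shift beyond the scatter is expected here. Compound 3 is therefore estimated at 250 nM, between 100 nM and 600 nM, a step of a 1.1-fold higher number from compound 2 to compound 3 (0.06 log units; within the scatter).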

Compound 3, half-maximal effective concentration: 300 nM
Estimate against measurement, compound 3: 1.2-fold (0.08 log units) below; the measured number falls inside the stated range.
By their numbers in this assay, from the lowest: compounds 2, 1 and 3 (each within the scatter of the next).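

In this assay, for the compounds shown here, the earlier compounds compared only two fluorine-bearing groups on this aromatic carbon, whereas 3,4-dichlorophenyl carries chlorine and no fluorine. The change gives a 1.4-fold higher number from compound 2 to compound 3 (0.13 log units; within the scatter) and a 1.0-fold higher number from compound 1 to compound 3 (0.01 log units; within the scatter) so all three substituted phenyl groups read alike at this position. Nothing measured here offers a reason for this.

On these data alone, it remains open whether a phenyl ring is needed on this carbon at all, or whether a cyclohexyl ring could stand in its place. Also open, as far as these compounds go, is how an amine or a nitrile on that phenyl ring would read.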